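Charged amine headgroup on a catechol chromone core

A few compounds are considered here, and "the series" means these few. Any claim that something is new, unique, unknown or untested is made for them only; others in the source may bear on it.

Measured so far, in a functional assay for inhibition, with Rattus norvegicus as the target, using microsomes; on this read-out lower numbers stand for stronger inhibition and higher numbers for weaker inhibition:
- compound 1, `C[N+](C)(C)CCCOc1ccc2c(=O)cc(-c3ccc(O)c(O)c3)oc2c1`, gives 37300 nM
- compound 2, `CN(C)CCCOc1ccc2c(=O)cc(-c3ccc(O)c(O)c3)oc2c1`, gives 8100 nM
- compound 3, `CN(C)CCCOc1c(-c2ccc(O)c(O)c2)oc2ccccc2c1=O`, gives 1000 nM

Compound 3 has the lowest number of the three measured compounds. Among the compounds with values here, its core and that of compound 2 are built from the same atoms joined differently; the difference between the two cores is not broken down here, and the two values show only that compound 3 sits well below compound 2.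

Going from compound 2 to compound 1 makes one change, (a group of 4 heavy atoms (3 carbon, 1 nitrogen; no ring) in place of a group of 3 heavy atoms (2 carbon, 1 nitrogen; no ring), on a saturated chain carbon, three bonds along the chain from an oxygen on an aromatic ring), and it gives a 4.6-fold higher number from compound 2 to compound 1 (0.66 log units; beyond the scatter). The unmeasured compound 4, `C[N+](C)(C)CCCOc1c(-c2ccc(O)c(O)c2)oc2ccccc2c1=O`, is derived from compound 3 by the same change, (a group of 4 heavy atoms (3 carbon, 1 nitrogen; no ring) in place of a group of 3 heavy atoms (2 carbon, 1 nitrogen; no ring), on a saturated chain carbon, three bonds along the chain from an oxygen on an aromatic ring), at the same place. Within the data shown here, because the one earlier instance of this change gave a 4.6-fold higher number from compound 2 to compound 1 (0.66 log units; beyond the scatter), a step of similar size is expected from compound 3 to compound 4, a 4.6-fold higher number from compound 3 to compound 4 (0.66 log units; beyond the scatter), resting on that single example alone. Compound 4 is therefore estimated at 4600 nM, with a plausible range from 1500 nM to 14000 nM.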

Compound 4, half-maximal inhibitory concentration: 1200 nM
For compound 4 the middle estimate is 3.8-fold (0.58 log units) above the measured one, and the stated range ends above it.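

In this assay, replacing dimethylamino with the group carrying a net charge of +1 gives a 1.2-fold higher number from compound 3 to compound 4 (0.08 log units; within the scatter) on the core of compound 3, so on this core the read-out shows no difference that can be told apart from the scatter of repeated measurements. The size of the step therefore did not carry over from one core to the other, and the two cores gave clearly different results for the same change: the same change on two cores in this assay, a 4.6-fold higher number (0.66 log units; beyond the scatter) from compound 2 to compound 1 and a 1.2-fold higher number (0.08 log units; within the scatter) from compound 3 to compound 4, 3.8-fold (0.58 log units) apart, beyond the scatter of two such steps
This shows that, in these two pairs, the effect of the change depends on the core, but two pairs cannot show which feature of the cores matters or what the change would do on a third core.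

From the compounds shown here alone, it remains open whether the same dependence on the core would appear with other amines, such as pyrrolidine or morpholine, in place of dimethylamino. Going by these compounds, a longer chain between the nitrogen and the oxygen on the aromatic ring is equally open.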